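This account rests on a few compounds, and the source may have more. Where it says the series, first, only, none or still open, it means among the compounds named here.

The shared core of compound 1 `CN1CCN(Cc2ccc(Nc3nc(Oc4ccc5ccc(=O)[nH]c5c4)c4sccc4n3)cc2)CC1`, compound 2 `CN1CCN(c2ccc(Nc3nc(Oc4ccc5ccc(=O)[nH]c5c4)c4sccc4n3)cc2)CC1` and compound 3 `CN1CCN(c2ccc(Nc3nc(Oc4ccc5ccc(=O)[nH]c5c4)c4sccc4n3)cc2F)CC1` carries a substituted aniline whose substituent changes from one compound to the next. In an ADME assay on L02 cells (Homo sapiens) for cytotoxicity, read by MTT assay, with a stated time of 72 h (a higher number here means a weaker inhibitor, a lower number a stronger inhibitor), compound 1 gives 7990 nM. Compound 2 reaches only the limit of this assay, giving > 50000 nM. Compound 3 gives 8370 nM in this assay. Compound 2 therefore stands at the top of the numbers shown, sitting at the limit of > 50000 nM in this assay, at which 1 of the 3 values shown sits, rather than at a number.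

Compound 4 `CCN1CCN(Cc2ccc(Nc3nc(Oc4ccc5ccc(=O)[nH]c5c4)c4sccc4n3)cc2)CC1` has not yet been measured. It differs from compound 2 by the change ((4-ethylpiperazin-1-yl)methyl in place of 4-methylpiperazin-1-yl on an aromatic carbon).

Among the compounds with values here, two measured steps bear on this change. The step of an at least 6.2-fold higher number from compound 1 to compound 2 (0.79 log units; beyond the scatter) shows that trading a methylene-linked methylpiperazine for a directly attached one moved the number up to the limit; the present change runs in the opposite direction and adds an ethyl in place of the methyl. The step of an at least 5.9-fold lower number from compound 2 to compound 3 (0.77 log units; beyond the scatter) shows that another single change at the aniline brought the number back down from the limit. He therefore expects the number to fall from compound 2 to compound 4 by about an at least 6.2-fold lower number from compound 2 to compound 4 (0.79 log units; beyond the scatter), landing near compound 1.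

For compound 4 he estimates 8000 nM in this assay, with a range from 3000 nM to 25000 nM.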

Compound 4, half-maximal inhibitory concentration: 5230 nM
Estimate against measurement, compound 4: 1.5-fold (0.18 log units) above; measured number inside the range.
By their numbers in this assay, from the lowest: compounds 4, 1 and 3 (each within the scatter of the next). At a limit, above all of these: compound 2.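

In this assay, putting (4-ethylpiperazin-1-yl)methyl in place of 4-methylpiperazin-1-yl gives an at least 9.5-fold lower number from compound 2 to compound 4 (0.98 log units; beyond the scatter), so a second compound with the methylene-linked piperazine now sits well clear of the limit reached by compound 2, and compound 1 no longer stands alone in this. Within the data shown here, the step of a 1.5-fold lower number from compound 1 to compound 4 (0.18 log units; within the scatter) adds what the earlier compounds could not show: with the methylene link in place, ethyl rather than methyl on the piperazine makes no difference that can be told from the scatter. Compound 2 holds a limit and not a number, so its steps give only a bound on their size, and among the directly attached compounds compound 3 goes against any simple reading of the link alone, since it too lies off the limit: the limit of > 50000 nM in this assay, at which 1 of the 4 values shown sits.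

The compounds shown leave open how a directly attached 4-ethylpiperazin-1-yl would read, and so whether ethyl matters when the methylene link is absent. They also leave open whether a larger group on that piperazine nitrogen, such as isopropyl or acetyl, or a morpholine in place of the piperazine, would keep the number in the same region.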